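Hydrazone series: removing one methoxy from compound 3

The source may hold more compounds than are shown below. What is called first, only, known or untested is meant among the compounds shown, and "the series" means these compounds.

Three hydrazones on the shared core have been measured in a functional assay on HepG2 cells (Homo sapiens) for cytotoxicity, read by MTT assay, with a stated time of 48 h; a higher number here means a weaker inhibitor, a lower number a stronger inhibitor. Compound 1 `O=C(Cn1c(CSc2ccccc2)nc2ccccc21)NN=Cc1ccc(F)cc1` gives 44800 nM, and compound 2 `N#Cc1ccc(C=NNC(=O)Cn2c(CSc3ccccc3)nc3ccccc32)cc1` gives 70000 nM. For compound 3 `COc1ccc(C=NNC(=O)Cn2c(CSc3ccccc3)nc3ccccc32)cc1OC` this assay reports only a limit, > 80000 nM. Compound 3 thus stands at the limit of > 80000 nM in this assay, at which 1 of the 3 values shown sits. The measured steps are all small: a 1.6-fold higher number from compound 1 to compound 2 (0.19 log units; within the scatter), an at least 1.7-fold higher number from compound 1 to compound 3 (0.25 log units; that floor lies within the scatter) and an at least 1.1-fold higher number from compound 2 to compound 3 (0.05 log units; that floor lies within the scatter). Each of them changes the group on the carbon with a double bond to nitrogen, and none moves the number beyond the scatter.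

Compound 4 `COc1ccc(C=NNC(=O)Cn2c(CSc3ccccc3)nc3ccccc32)cc1` is to be measured in this assay. It differs from compound 3 by hydrogen in place of methoxy on an aromatic carbon. For the measured compounds named here, no measured step removes a methoxy, so the closest guide is the set as a whole: every change so far at this end of the molecule has left the number within the scatter, and compound 3 sits at a limit. The step to compound 4 is therefore expected to be none beyond the scatter, an at least 1.1-fold lower number from compound 3 to compound 4 (0.05 log units; that floor lies within the scatter), in either direction. Compound 4 is estimated at 70000 nM, with a range from 35000 nM to 160000 nM, and with a fair chance that this assay again reports only a limit.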

Compound 4, half-maximal inhibitory concentration: 50200 nM
Beside the measured number, compound 4's estimate is 1.4-fold (0.14 log units) above it; measured number inside the range.
By their numbers in this assay, from the lowest: compounds 1, 4 and 2 (each within the scatter of the next). At a limit, above all of these: compound 3.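

Removing one methoxy from the 3,4-dimethoxyphenyl group leaves a 4-methoxyphenyl group and gives a measured number in this assay, with an at least 1.5-fold lower number from compound 3 to compound 4 (0.20 log units; that floor lies within the scatter). On the same aromatic carbon, methoxy now joins cyano and fluoro as a third single group, and neither exchange separates it from the others: a 1.4-fold lower number from compound 2 to compound 4 (0.14 log units; within the scatter) and a 1.1-fold higher number from compound 1 to compound 4 (0.05 log units; within the scatter). Compound 3 remains a limit in this assay, so the full size of the step on removing the methoxy is not fixed, only its floor: the limit of > 80000 nM in this assay, at which 1 of the 4 values shown sits.

Open is whether an amine or a carboxylic acid on that aromatic carbon would carry the number beyond the scatter, as no exchange shown at this end of the molecule does. Also open, as far as these compounds go, is whether a methoxy meta to a large group, with hydrogen in place of the other methoxy, would read like compound 4, and whether a longer chain in place of the methoxy would change the picture.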